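This account rests on a few compounds, and the source may have more. Where it says the series, first, only, none or still open, it means among the compounds named here.

Three compounds share one core and differ only in the group on the sulfonyl sulfur. Compound 3 `CS(=O)(=O)Nc1ccc(-c2nc3ccccc3o2)cc1` carries a methyl there. In an assay on isolated protein for inhibition of malate dehydrogenase, mitochondrial (Sus scrofa), with stated times of 45 min and 30 min (a lower number here means a stronger inhibitor, a higher number a weaker inhibitor), compound 3 reaches only a limit, > 63000 nM. Compound 1 `O=S(=O)(Nc1ccc(-c2nc3ccccc3o2)cc1)c1cccc(F)c1` carries 3-fluorophenyl, and in this assay compound 1 likewise gives only a limit, > 63000 nM. Compound 2 `O=S(=O)(Nc1ccc(-c2nc3ccccc3o2)cc1)c1ccc(Cl)s1` carries 5-chlorothiophen-2-yl, and in this assay compound 2 also gives only a limit, > 63000 nM. Compound 3 thus sits with the other two at the limit of > 63000 nM in this assay, at which 3 of the 3 values shown sit. Compound 4 `O=S(=O)(Nc1ccc(-c2nc3ccccc3o2)cc1)c1ccccc1F` makes the change (2-fluorophenyl in place of methyl on a sulfonyl sulfur). Since the steps a step that the two limits leave unreadable from compound 1 to compound 3 and a step that the two limits leave unreadable from compound 2 to compound 3 could not be sized, no shift beyond the scatter is expected, and the estimated step is a step that the limit leaves unreadable from compound 3 to compound 4. Compound 4 is expected at 100000 nM, between 30000 nM and 400000 nM, most probably again only as a limit.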

Compound 4, half-maximal inhibitory concentration: > 63000 nM
Compound 4: a limit, no number; the forecaster's own chance of this, stated with the estimate: 85%; the middle value is on the limit's open side.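

Going by these compounds alone, compound 4 also gives only a limit in this assay, so no step to it from compound 1, compound 2 or compound 3 can be read. The compounds shown leave open whether any of these groups on the sulfonyl sulfur alters inhibition, because all share one limit: the limit of > 63000 nM in this assay, at which 4 of the 4 values shown sit.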